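A few compounds are considered here, and "the series" means these few. Any claim that something is new, unique, unknown or untested is made for them only; others in the source may bear on it.

Measured compounds:
compound 1 `CC1(C)c2[nH]nc(NC(=O)c3ccc(Br)cc3)c2CN1Cc1cccc(F)c1F` — 950 nM
compound 2 `CN(C)c1ccc(C(=O)Nc2n[nH]c3c2CN(Cc2cccc(F)c2F)C3(C)C)cc1` — 69 nM

In an assay on Sf21 cells for inhibition of high affinity nerve growth factor receptor (Homo sapiens), read by HTRF, with a stated time of 30 min, in the presence of a further agent that is not named here (a lower number here means a stronger inhibitor, a higher number a weaker inhibitor), compound 2 gives 69 nM and so stands at the lower of the two numbers measured. Among the measured compounds shown here, its nearest neighbour is compound 1, which in this assay gives 950 nM; the single step between them, a 14-fold lower number from compound 1 to compound 2 (1.14 log units; beyond the scatter), is large and well beyond the scatter.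

Compound 3 `CN(C)c1cccc(C(=O)Nc2n[nH]c3c2CN(Cc2cccc(F)c2F)C3(C)C)c1` is the next compound to consider. It is built from the same atoms as compound 2, joined differently: 3-(dimethylamino)phenyl in place of 4-(dimethylamino)phenyl on a carbonyl carbon. The dimethylamino group thus keeps its identity but moves to another position on the benzene ring of the amide.

For the measured compounds named here, only one measured step exists, and it concerns the exchange of bromo for dimethylamino rather than a shift of the same group around the ring. It therefore shows how much this group matters when present, but says nothing about where on the ring it must sit. Without a step of the same kind, the expectation for compound 3 can only be cautious: a modest move towards a higher number is expected, a 2.2-fold higher number from compound 2 to compound 3 (0.34 log units; beyond the scatter), with a wide margin either way. Compound 3 is estimated at 150 nM, expected to lie between 40 nM and 600 nM.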

Compound 3, half-maximal inhibitory concentration: 420 nM
For compound 3 the middle estimate is 2.8-fold (0.45 log units) below the measured one, within the range that was stated.
By their numbers in this assay, from the lowest: compound 2; then compound 3; then compound 1.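

In this assay, the result shows that the place of the dimethylamino group on the benzene ring matters, not only its presence: the same atoms, joined differently, give a 6.1-fold higher number from compound 2 to compound 3 (0.78 log units; beyond the scatter) on moving from 4-(dimethylamino)phenyl to 3-(dimethylamino)phenyl. Only part of the gain seen on replacing bromo carries over to the new position, as 4-(dimethylamino)phenyl in place of 4-bromophenyl gives a 14-fold lower number from compound 1 to compound 2 (1.14 log units; beyond the scatter) while 3-(dimethylamino)phenyl in the same exchange gives a 2.3-fold lower number from compound 1 to compound 3 (0.35 log units; beyond the scatter) and so a smaller improvement. Among these three amide groups, 4-(dimethylamino)phenyl therefore gives the lowest number, and 3-(dimethylamino)phenyl still keeps an advantage over 4-bromophenyl that lies beyond the scatter.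

Nothing available here explains why moving the group on the ring raises the number. Also open, from the compounds shown here alone, is whether another amine in place of dimethylamino, such as morpholine or piperazine, would keep or lower the number of compound 2.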